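This account rests on a few compounds, and the source may have more. Where it says the series, first, only, none or still open, it means among the compounds named here.

Measured compounds in an ADME assay for pharmacokinetics, read by LC-MS, in phosphate buffer, with a stated time of 72 h, at pH 7.4, tested at 250 uM; on this read-out higher numbers stand for a longer-lived compound and lower numbers for a shorter-lived compound:
- compound 1 `C=CC(=O)Nc1cc(C(F)(F)F)cc(C(F)(F)F)c1` gives 1.8 h.
- compound 2 `C=CS(=O)(=O)c1cc(C(F)(F)F)cc(C(F)(F)F)c1` gives a limit of the assay, < 0.017 h.
- compound 3 `C=Cc1cc(C(F)(F)F)cc(C(F)(F)F)c1` gives a limit of the assay, > 50 h.

Compound 3 stands at the top of the three numbers, at the limit of > 50 h in this assay, at which 1 of the 3 values shown sits. Compound 2 stands at the bottom, at the limit of < 0.017 h in this assay, at which 1 of the 3 values shown sits. Every measured step changes the group on the same aromatic carbon, and every one is large: an at least 100-fold lower number from compound 1 to compound 2 (2.02 log units; beyond the scatter), an at least 27-fold higher number from compound 1 to compound 3 (1.44 log units; beyond the scatter), an at least 2900-fold higher number from compound 2 to compound 3 (3.46 log units; beyond the scatter).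

Compound 4 `FC(F)(F)c1cc(S)cc(C(F)(F)F)c1` differs from compound 3 by sulfanyl in place of vinyl on an aromatic carbon. Among the compounds with values here, no measured step involves sulfanyl, so none bears directly on this change; what the three steps do show is that each exchange of the group on this carbon moved this assay by a large amount. A large step is therefore expected here too, and since the value of compound 3 is a limit at the top, any step that is recorded can only run to lower numbers. The step expected is an at least 6.2-fold lower number from compound 3 to compound 4 (0.79 log units; beyond the scatter). Compound 4 is estimated at 8 h in this assay, between 0.5 h and 50 h.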

Compound 4, half-life: > 50 h
Compound 4 gave a limit, no number (the forecaster's own chance of this, stated with the estimate: 25%); middle value at least 6.2-fold (0.79 log units) away from the limit.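

In this assay, compound 4 gives a limit and not a number, and the top of the series is now shared: the limit of > 50 h in this assay, at which 2 of the 4 values shown sit. The step between compound 3 and compound 4 cannot be read, as both values are limits, so vinyl and sulfanyl cannot be ordered on this carbon. The readable steps are an at least 2900-fold higher number from compound 2 to compound 4 (3.46 log units; beyond the scatter) and an at least 27-fold higher number from compound 1 to compound 4 (1.44 log units; beyond the scatter), which show that a half-life reaching the top limit on this carbon is not confined to vinyl.

From the compounds shown here alone, how far compound 3 and compound 4 would extend past the limit remains open. So does whether an amine, a carboxylic acid or a nitrile on this carbon would also reach the limit or give a number within the range of this assay.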